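The source may hold more compounds than are shown below. What is called first, only, known or untested is meant among the compounds shown, and "the series" means these compounds.

The two measured compounds share one core and differ in the side chain on the amine and in the aryl chain. In an assay on HEK293 cells for displacement of a labelled ligand from Melanocortin receptor 4 (Homo sapiens) (a higher number here means a weaker inhibitor, a lower number a stronger inhibitor), compound 1 `CC(C)C[C@H](N)c1cc(C(F)(F)F)ccc1N1CCN(C(=O)CCc2ccccc2Cl)CC1` gives 1700 nM. In this assay compound 2 `CCC(C)[C@H](NCC1CCCO1)c1cc(C(F)(F)F)ccc1N1CCN(C(=O)CCc2ccc(Cl)cc2Cl)CC1` gives 780 nM, the lower of the two numbers, with compound 1 standing higher by a gap beyond the usual scatter. Compound 3 `CCC(C)[C@H](NC(=O)CN)c1cc(C(F)(F)F)ccc1N1CCN(C(=O)CCc2ccc(Cl)cc2Cl)CC1` carries (aminomethyl)carbonyl in place of (oxolan-2-yl)methyl on an amine nitrogen. For the measured compounds named here, no measured pair shows this change, so its size is open. Compound 3 is estimated at 1200 nM, between 400 nM and 4000 nM. This is expected to mean a step of a 1.5-fold higher number from compound 2 to compound 3 (0.19 log units; within the scatter), a small weakening at most, possibly within the scatter.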

Compound 3, inhibition constant: 18 nM
For compound 3 the middle estimate is 67-fold (1.82 log units) above the measured one, outside the stated range (below it).
By their numbers in this assay, from the lowest: compound 3; then compound 2; then compound 1.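

For the compounds shown here, on this amine nitrogen, the substituent matters far more than the earlier compounds could show: in this assay, (aminomethyl)carbonyl in place of (oxolan-2-yl)methyl gives a 43-fold lower number from compound 2 to compound 3 (1.64 log units; beyond the scatter). The five-membered ring of the leaving group is thus not needed for a low number in this series, as compound 3 has no ring at this position. Nothing available explains the size of this step.

The compounds shown leave open how much of the step belongs to the carbonyl and how much to the amine of the new group. An acetyl group or a longer aminoacyl chain on that nitrogen would separate the two.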